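This account rests on a few compounds, and the source may have more. Where it says the series, first, only, none or still open, it means among the compounds named here.

Of the compounds shown here, three have been measured in an ADME assay on RAW264.7 cells (Mus musculus) for cytotoxicity, read by MTT assay, with a stated time of 24 h, tested at 1.25 ug/mL; a lower number here means a stronger effect, a higher number a weaker effect of the compound at the concentration tested: compound 1 `COc1ccc(C(=O)/C=C/c2ccc(OC)c(OC)c2OC)c(O)c1` gives 98.5%, compound 2 `COc1ccc(C(=O)/C=C/c2cccc(OC)c2OC)c(O)c1` gives 94.2%, and compound 3 `COc1ccc(CCCc2ccc(OC)c(OC)c2OC)c(O)c1` gives 96.3%.

Compound 2 differs from compound 1 by one change, (hydrogen in place of methoxy on an aromatic carbon). In this assay this change made a step of a number 4.3 percentage points lower from compound 1 to compound 2 (within the scatter). Compound 3 carries a different core from compound 1; the difference between the two cores is not broken down here. In this assay compound 3 and compound 1 give numbers within the scatter of each other.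

Compound 4 `COc1ccc(CCCc2cccc(OC)c2OC)c(O)c1` has not yet been measured. It differs from compound 3 by hydrogen in place of methoxy on an aromatic carbon, the same change as that from compound 1 to compound 2, made at the same kind of place. For compound 4 in this assay the step from its parent is expected to be a number 3.3 percentage points lower from compound 3 to compound 4 (within the scatter), small because the earlier step of a number 4.3 percentage points lower from compound 1 to compound 2 (within the scatter) was small. Compound 4 is therefore estimated at 93%, with a likely range from 84% to 100%.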

Compound 4, a percentage reported as activity, at one concentration (the size of the read-out at that concentration, not a potency): 99.1%
For compound 4 the middle estimate is 6.1 percentage points below the measured one, within the range that was stated.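

In this assay, among the compounds shown here, hydrogen in place of methoxy on an aromatic carbon gave a number 2.8 percentage points higher from compound 3 to compound 4 (within the scatter), so on the core of compound 3 the change left no step that stands out from repeated measurement. Set beside the earlier step on the core of compound 1, the two steps point in opposite directions, yet they cannot be told apart: the same change on two cores in this assay, a number 4.3 percentage points lower (within the scatter) from compound 1 to compound 2 and a number 2.8 percentage points higher (within the scatter) from compound 3 to compound 4, 7.1 percentage points apart, within the scatter of two such steps This shows that the change left the read-out within the scatter on both cores, but it does not show that the change has a shared effect that carries from one core to the other, nor does it give any direction for such an effect, and it rests on only two pairs at a single tested concentration.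

The compounds shown carry only methoxy or hydrogen at this place, so it stays open how an amine, a chlorine atom or a carboxylic acid there would read in this assay. Also open, going by these compounds, is whether a longer chain in the core of compound 3 would give a different read-out.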